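The source may hold more compounds than are shown below. What is called first, only, known or untested is meant among the compounds shown, and "the series" means these compounds.

Compound 1, `CN1C(=S)[C@@H](NC(=O)c2nc(Cc3ccccc3)n(CCCC#N)n2)COc2ccccc21`, in a toxicity assay on HT-29 cells (Homo sapiens) for cytotoxicity (a higher number here means that more compound is tolerated, a lower number that less compound is tolerated), gives a limit of > 100000 nM.
Compound 2, `CN1C(=S)[C@@H](NC(=O)c2nc(Cc3ccccc3)n(C3CCC3)n2)COc2ccccc21`, in this assay gives a limit of > 100000 nM.
Compound 3, `CN1C(=S)[C@@H](NC(=O)c2nc(Cc3ccccc3)n(-c3ncccn3)n2)COc2ccccc21`, in this assay gives a limit of > 100000 nM.

Compound 1 stands at the same limit as the two other measured compounds; in this assay none of the three gives a number. Compound 4, `Cc1cnc(-n2nc(C(=O)N[C@H]3COc4ccccc4N(C)C3=S)nc2Cc2ccccc2)nc1`, differs from compound 1 in one place: 5-methylpyrimidin-2-yl in place of 3-cyanopropyl on an aromatic nitrogen. The measured steps that bear on this change are a step that the two limits leave unreadable from compound 1 to compound 2 and a step that the two limits leave unreadable from compound 1 to compound 3, and also a step that the two limits leave unreadable from compound 2 to compound 3; none of them can be sized, because of the limit of > 100000 nM in this assay, at which 3 of the 3 values shown sit. Every change tried so far at the same aromatic nitrogen has left the cytotoxicity at its limit, so no step beyond the scatter is expected in this assay in either direction. Compound 4 is therefore expected to be tolerated at the limit as well. The estimate for compound 4 is 150000 nM, with a range from 50000 nM to 500000 nM. For compound 4 this means an expected step that the limit leaves unreadable from compound 1 to compound 4.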

Compound 4, half-maximal cytotoxic concentration: > 100000 nM
Compound 4 gave a limit, no number; the forecaster's own chance of this, stated with the estimate: 85%; the middle value does not contradict the limit.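

No step from compound 1, compound 2 or compound 3 to compound 4 can be read, because all four compounds stop at the same limit: the limit of > 100000 nM in this assay, at which 4 of the 4 values shown sit.

As far as these compounds go, whether any group on the aromatic nitrogen would give an actual number in this assay stays open.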